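A few compounds are considered here, and "the series" means these few. Any claim that something is new, unique, unknown or untested is made for them only; others in the source may bear on it.

Compound 1 `Cn1c(Cc2nn(C)c(=O)c3ccccc23)nnc1SCCCCCCCC(=O)Nc1ccc(I)cc1`: 1300 nM
Compound 2 `Cn1c(Cc2nn(C)c(=O)c3ccccc23)nnc1SCCCCCCCCCC(=O)Nc1ccc(Cl)cc1Cl`: 2300 nM

Of the compounds shown here, two have been measured in an assay on isolated protein (Mus musculus) for inhibition of IL15-IL15 receptor (Homo sapiens), read by resazurin assay, with stated times of 30 min and 2.5 days; a lower number here means a stronger inhibitor, a higher number a weaker inhibitor. Compound 1 gives 1300 nM and compound 2 gives 2300 nM; the two numbers lie within the scatter of each other, so neither can be called the stronger inhibitor. Compound 1 has the lowest of the two numbers, compound 2 is nearest to it, and the gap between them lies within the scatter.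

Compound 3 `COc1ccc(NC(=O)CCCCCCCSc2nnc(Cc3nn(C)c(=O)c4ccccc34)n2C)cc1` has not yet been measured in this assay. It differs from compound 1 in one place: methoxy in place of iodo on an aromatic carbon. Among the measured compounds shown here, no step between measured compounds that differ in one place is available, so there is no direct guide to how this kind of change has played out before. What is known is that both measured compounds sit in the same range, with compound 1 at 1300 nM and compound 2 at 2300 nM. A small step, a 1.5-fold higher number from compound 1 to compound 3 (0.19 log units; within the scatter), is expected, with no clear direction beyond the scatter. Compound 3 is estimated at 2000 nM, within 800 nM to 5000 nM.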

Compound 3, half-maximal inhibitory concentration: 3900 nM
Compound 3: the middle estimate sits 2.0-fold (0.29 log units) below what was measured; the measured number falls inside the stated range.
By their numbers in this assay, from the lowest: compounds 1, 2 and 3 (each within the scatter of the next, the first and the last beyond it).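

In this assay, replacing iodo with methoxy on the aromatic ring gives a 3.0-fold higher number from compound 1 to compound 3 (0.48 log units; beyond the scatter), a modest step but the first one here that clears the usual scatter. Among the compounds shown here, this gives the first sign that the group at this place, para to a large group, can change the measured inhibition even while the rest of compound 1 stays the same, and that 4-iodophenyl gives the lower number of these two end groups. The change also swaps a group with no hydrogen-bond acceptor for one with a single acceptor and adds one heavy atom, but no measurement here connects either difference to the step or explains it in any other way.

One pair cannot show whether iodo lowers the number or methoxy raises it, and a plain phenyl ring with only hydrogen at this place would help separate those two readings. On these data alone, it also remains open how other groups would fare here, such as fluoro, chloro, trifluoromethyl, an amine or a carboxylic acid, and whether the same swap would give a similar step with a different chain.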